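Difluorophenyl for Methoxyphenyl on the Carbonyl Carbon

The compounds below may be only part of what the source reports. "The series", "measured", "known", "first", "only" and "open" are said of these compounds alone.

Three compounds have been measured in a functional assay on OVCAR-8 cells (Homo sapiens) for cytotoxicity, read by sulforhodamine B assay, with a stated time of 48 h, tested at 0.1 uM; a lower number here means a stronger effect, a higher number a weaker effect of the compound at the concentration tested:
compound 1 `COc1cc(-c2cc(/C=C/C(=O)c3ccc(Cl)c(Cl)c3)[nH]n2)cc(OC)c1OC` gives 97%
compound 2 `COc1ccc(C(=O)/C=C/c2cc(-c3cc(OC)c(OC)c(OC)c3)n[nH]2)cc1` gives 98%
compound 3 `COc1cc(C(=O)/C=C/c2cc(-c3cc(OC)c(OC)c(OC)c3)n[nH]2)cc(OC)c1OC` gives 94%

Compound 2 holds the highest of the three numbers in this assay, yet all three lie within the scatter of one another, so no order among them can be claimed. Going by the values given here, the single measured step that touches the group on the carbonyl carbon, a number 1 percentage points higher from compound 1 to compound 2 (within the scatter), exchanges 3,4-dichlorophenyl for 4-methoxyphenyl and stays within the scatter. Compound 3 also sits within the scatter of compound 2.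

Compound 4 `COc1cc(-c2cc(/C=C/C(=O)c3ccc(F)c(F)c3)[nH]n2)cc(OC)c1OC` differs from compound 2 by 3,4-difluorophenyl in place of 4-methoxyphenyl on a carbonyl carbon. Among the compounds with values here, the entering 3,4-difluorophenyl group resembles the 3,4-dichlorophenyl group of compound 1, and the only step that bears on this place, a number 1 percentage points higher from compound 1 to compound 2 (within the scatter), was flat. Compound 4 is therefore expected to give 96% in this assay, with a range from 86% to 104%. The step expected in this assay, a number 2 percentage points lower from compound 2 to compound 4 (within the scatter), is none beyond the scatter.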

Compound 4, a percentage reported as activity, at one concentration (the size of the read-out at that concentration, not a potency): 96%
Estimate against measurement, compound 4: no gap at the digits printed, and the stated range covers the measured number.
By their numbers in this assay, from the lowest: compounds 3, 4, 1 and 2 (each within the scatter of the next).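

In this assay, the step of a number 2 percentage points lower from compound 2 to compound 4 (within the scatter) sets 3,4-difluorophenyl against 4-methoxyphenyl on the carbonyl carbon, and the step of a number 1 percentage points lower from compound 1 to compound 4 (within the scatter) sets it against 3,4-dichlorophenyl, so neither exchange goes beyond the scatter. Going by these compounds alone, the single earlier step compared only two groups at this position, whereas three phenyl groups with different substituents now give numbers that cannot be told apart at the one concentration tested. No measurement offered here explains this flat result.

From the compounds shown here alone, it remains open whether a group of another kind on the carbonyl carbon, such as an amine or a carboxylic acid, would give a number beyond the scatter of these three. A single-concentration read-out also gives no potency, so any differences among these compounds at other concentrations remain unknown.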